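Ethoxy to butoxy: from compound 2 to compound 3

A few compounds are considered here, and "the series" means these few. Any claim that something is new, unique, unknown or untested is made for them only; others in the source may bear on it.

Measured so far in an ADME assay on HaCaT cells (Homo sapiens) for antiproliferative activity, with a stated time of 48 h; a lower number here means a stronger inhibitor, a higher number a weaker inhibitor:
- compound 1 `CN1CCN(c2ccc(-c3cccc(C(F)(F)F)c3)nn2)CC1`: > 25000 nM
- compound 2 `CCOC(=O)c1ccc(-c2ccc(OCC)nn2)cc1`: > 25000 nM

Neither entry is a number, and each is a limit of the assay. Compound 2 stands at > 25000 nM, which is a limit. The series therefore sits at a single point so far, (the limit of > 25000 nM in this assay, at which 2 of the 2 values shown sit).

Compound 3 `CCCCOc1ccc(-c2ccc(C(=O)OCC)cc2)nn1` differs from compound 2 in one place: ethyl in place of hydrogen on a saturated chain carbon, two bonds along the chain from an oxygen on an aromatic ring. The same difference reads as ethoxy to butoxy. For the measured compounds named here, no measured pair isolates a change of this kind, so the data give neither a size nor a direction for it. Going by the values given here, the only anchor is compound 2, whose > 25000 nM is a limit. In this assay no step beyond the scatter is expected, and another limit is the likeliest report. The estimated step of a number no higher from compound 2 to compound 3 (the limit leaves the size open) is accordingly expected to be small, though with wide uncertainty. For compound 3 the expected value is 25000 nM, with an estimated range of 9000 nM to 40000 nM.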

Compound 3, half-maximal inhibitory concentration: > 25000 nM
Compound 3: only a limit was reported (the forecaster's own chance of this, stated with the estimate: 65%); the middle value sits exactly at the limit.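

In this assay compound 3 gives > 25000 nM, a limit of the assay. For the compounds shown here, compound 2 also stands at a limit, and no step from ethoxy to butoxy can be read between compound 2 and compound 3. The compounds shown leave open whether any change to these structures gives a measurable number in this assay: the limit of > 25000 nM in this assay, at which 3 of the 3 values shown sit.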